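Trimming compound 1 to compound 3: stability expected to rise

The compounds below may be only part of what the source reports. "The series", "measured", "known", "first", "only" and "open" are said of these compounds alone.

Compound 1 `FC1(F)CCC(CN(C[C@H]2Cc3c(cccc3N3CCNCC3)CN2)[C@H]2CCCc3cccnc32)CC1` was examined in an ADME assay on microsomes from liver (Homo sapiens) for metabolic stability, read by LC-MS, with a stated time of 10 min (on this read-out higher numbers stand for a more stable compound and lower numbers for a less stable compound), where compound 1 gives 68.6%, the lower of the two numbers recorded. Compound 2 `CN(C[C@H]1Cc2c(cccc2N2C[C@H]3C[C@@H]2CN3)CN1)[C@H]1CCCc2cccnc21` gives 100% in this assay, a reading that lies beyond the scatter above compound 1. Compound 3 `CN(C[C@H]1Cc2c(cccc2N2CCNCC2)CN1)[C@H]1CCCc2cccnc21` has not been measured. It differs from compound 1 by hydrogen in place of 4,4-difluorocyclohexyl on a saturated chain carbon bound to an amine nitrogen. Among the compounds with values here, no step between measured compounds covers this change, so the expectation rests on compound 2, whose reading of 100% comes with the same methyl that compound 3 carries. Compound 3 is therefore expected to shift upward by a number 21.4 percentage points higher from compound 1 to compound 3 (beyond the scatter), beyond the scatter. Compound 3 is estimated at 90%, within 72% to 100%.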

Compound 3, percent of the compound remaining: 99.7%
For compound 3 the middle estimate is 9.7 percentage points below the measured one, within the range that was stated.
By their numbers in this assay, from the lowest: compound 1; then compounds 3 and 2 (each within the scatter of the next).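

Taking away 4,4-difluorocyclohexyl, with hydrogen entering on a saturated chain carbon bound to an amine nitrogen, gives in this assay a number 31.1 percentage points higher from compound 1 to compound 3 (beyond the scatter), so this position now has a direct one-place comparison. On an aromatic carbon, the group of 6 heavy atoms in place of the group of 7 gives a number 0.3 percentage points lower from compound 2 to compound 3 (within the scatter), so that exchange does not separate the two compounds. No measurement bears on the reason for either result.

The compounds shown leave open whether a plain cyclohexyl or a short chain such as ethyl at this position would read with compound 1 or with compound 3.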